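Moving the fluorine on the alkyne-linked phenyl ring

A few compounds are considered here, and "the series" means these few. Any claim that something is new, unique, unknown or untested is made for them only; others in the source may bear on it.

The measured compounds were tested in a functional assay on MCF7 cells (Homo sapiens) for inhibition, read by sulforhodamine B assay, with a stated time of 48 h; on this read-out lower numbers stand for stronger inhibition of growth and higher numbers for weaker inhibition of growth:

Compound 1 `COC(=O)c1sc2cc(C#Cc3ccc(N)cc3)cnc2c1N` gives 2600 nM.
Compound 3 `COC(=O)c1sc2cc(C#Cc3ccccc3N)cnc2c1N` gives 4100 nM.
Compound 2 `COC(=O)c1sc2cc(C#Cc3ccccc3F)cnc2c1N` gives only a limit of the assay, > 150000 nM.

Compound 2 thus stands at the weak end of the three, sitting at the limit of > 150000 nM in this assay, at which 1 of the 3 values shown sits, with an at least 57-fold higher number from compound 1 to compound 2 (1.76 log units; beyond the scatter) and an at least 36-fold lower number from compound 2 to compound 3 (1.56 log units; beyond the scatter) both placing it well apart from the two amino-bearing compounds. The step to the unmeasured compound 4 `COC(=O)c1sc2cc(C#Cc3ccc(F)cc3)cnc2c1N` is 4-fluorophenyl in place of 2-fluorophenyl on a triple-bonded carbon. The same fluorine stays, only its place on the phenyl ring changes.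

The closest guide among the measured steps is the swap of an amino group between the same two positions, a 1.6-fold higher number from compound 1 to compound 3 (0.20 log units; within the scatter), which stayed within the scatter. The large steps of an at least 57-fold higher number from compound 1 to compound 2 (1.76 log units; beyond the scatter) and an at least 36-fold lower number from compound 2 to compound 3 (1.56 log units; beyond the scatter) concern replacing fluoro by amino and do not bear directly on a change of position alone. On that basis, no step beyond the scatter is expected in this assay from compound 2 to compound 4, with the caveat that compound 2 is known only as a limit. Compound 4 is therefore expected to remain weak, near 120000 nM with a range of 25000 nM to 400000 nM, an expected step of an at least 1.2-fold lower number from compound 2 to compound 4 (0.09 log units; that floor lies within the scatter).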

Compound 4, concentration for 50% growth inhibition: 29000 nM
For compound 4 the middle estimate is 4.1-fold (0.62 log units) above the measured one; low and high end bracket the measured number.
By their numbers in this assay, from the lowest: compounds 1 and 3 (each within the scatter of the next); then compound 4. At a limit, above all of these: compound 2.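

In this assay, the place of the fluorine on the phenyl ring matters in a way the place of the amino group did not: 4-fluorophenyl in place of 2-fluorophenyl gives an at least 5.1-fold lower number from compound 2 to compound 4 (0.71 log units; beyond the scatter), whereas swapping the two aminophenyl groups gave a 1.6-fold higher number from compound 1 to compound 3 (0.20 log units; within the scatter). The better-placed fluorine still does not match either amino compound, with an 11-fold higher number from compound 1 to compound 4 (1.05 log units; beyond the scatter) and a 7.1-fold higher number from compound 3 to compound 4 (0.85 log units; beyond the scatter). So amino in place of fluoro lowers the number in both fluorine placements, but the size of that gain depends on which fluorophenyl compound it starts from, something a single amino-for-fluoro step could not reveal: the same change on two cores in this assay, an at least 36-fold lower number (1.56 log units; beyond the scatter) from compound 2 to compound 3 and an 11-fold lower number (1.05 log units; beyond the scatter) from compound 4 to compound 1, at least 3.2-fold (0.51 log units) apart, beyond the scatter of two such steps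

As far as these compounds go, compound 2 stands only as a limit of the assay, > 150000 nM, so the full size of every step that touches it stays open. Also open, from the compounds shown here alone, is whether a hydroxyl group, a methoxy group or a carboxylic acid on the phenyl ring would behave like the amino group or like the fluorine in this assay.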